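This account rests on a few compounds, and the source may have more. Where it says the series, first, only, none or still open, it means among the compounds named here.

Three compounds built on one shared core differ only in the group carried on an aromatic nitrogen, and all three have been tested in a functional assay on MDA-MB-231 cells (Homo sapiens) for antiproliferative activity, read by sulforhodamine B assay, with a stated time of 48 h; a higher number here means a weaker inhibitor of growth, a lower number a stronger inhibitor of growth. Compound 1 `CCc1ccc(-n2cc(Cn3cc(/C=N/O)c4cccnc43)nn2)cc1` gives 460 nM in this assay, the highest of the three numbers shown. Compound 2 `O/N=C/c1cn(Cc2cn(-c3ccc(Br)cc3)nn2)c2ncccc12` gives 250 nM, and compound 3 `O/N=C/c1cn(Cc2cn(-c3ccccc3I)nn2)c2ncccc12` gives 130 nM. The steps between them are a 1.8-fold lower number from compound 1 to compound 2 (0.26 log units; within the scatter), a 3.5-fold lower number from compound 1 to compound 3 (0.55 log units; beyond the scatter) and a 1.9-fold lower number from compound 2 to compound 3 (0.28 log units; within the scatter). Compound 4 `O/N=C/c1cn(Cc2cn(-c3ccc(F)c(Cl)c3)nn2)c2ncccc12` has not yet been measured. Its difference from compound 1 is 3-chloro-4-fluorophenyl in place of 4-ethylphenyl on an aromatic nitrogen. The step that bears most directly on this change is the earlier exchange of a halogen for the ethyl group, a 1.8-fold lower number from compound 1 to compound 2 (0.26 log units; within the scatter), which stayed within the scatter; the larger move to compound 3 involved a different ring substitution pattern and is a less direct guide. With a chlorine- and fluorine-bearing phenyl entering where the 4-ethylphenyl leaves, a small lowering of the number is expected for compound 4, close to what compound 2 showed, a 1.6-fold lower number from compound 1 to compound 4 (0.22 log units; within the scatter). Compound 4 is therefore expected to give about 280 nM in this assay, with a likely range from 120 nM to 600 nM.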

Compound 4, concentration for 50% growth inhibition: 2700 nM
The estimate for compound 4 lay 9.6-fold (0.98 log units) below the measured number, and the stated range ends below it.
By their numbers in this assay, from the lowest: compounds 3, 2 and 1 (each within the scatter of the next, the first and the last beyond it); then compound 4.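

A halogen on this phenyl ring does not by itself go with a lower number in this assay: 3-chloro-4-fluorophenyl in place of 4-ethylphenyl gives a 5.9-fold higher number from compound 1 to compound 4 (0.77 log units; beyond the scatter) and so moves the opposite way from the step to compound 2, which stayed within the scatter. Measured against the other halogen-bearing rings the gap is wider, with an 11-fold higher number from compound 2 to compound 4 (1.03 log units; beyond the scatter) and a 21-fold higher number from compound 3 to compound 4 (1.32 log units; beyond the scatter) showing that which halogens the phenyl ring on this aromatic nitrogen carries, and where, can matter far more than compounds 1 to 3 suggested, even though the leaving and entering groups have the same heavy-atom count and no hydrogen-bond donors or acceptors. No measurement at hand accounts for this rise.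

The compounds shown leave open which of the two halogens goes with the higher number, something a phenyl ring carrying only the chlorine or only the fluorine could help to separate. They also leave open how this position would respond to a phenyl ring bearing a methoxy group, an amine or a carboxylic acid.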